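The source may hold more compounds than are shown below. What is called first, only, known or untested is meant among the compounds shown, and "the series" means these compounds.

Measured so far:
Compound 1 `C[C@@H]1CN(c2sc(C(F)(F)F)nc2-c2nc3ccccc3[nH]2)CCN1C(=O)Cn1cccn1` gives 191 nM in a functional assay on Venous blood for antagonist activity at C-X-C chemokine receptor type 3 (Homo sapiens), read by flow cytometry, with a stated time of 30 min, in the presence of a further agent that is not named here; a higher number here means a weaker inhibitor, a lower number a stronger inhibitor.
Compound 2 `Cc1nc(C)n(CC(=O)N2CCN(c3sc(C(F)(F)F)nc3-c3nc4ccc(C5CCOCC5)cc4[nH]3)C[C@H]2C)n1` gives 123 nM in this assay.

Among the compounds with values here, compound 1 and compound 2 lie within the scatter of each other, so compound 1 cannot be placed above or below compound 2 on these two numbers; no step between them is counted.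

Compound 3 `C[C@@H]1CN(c2sc(C(F)(F)F)nc2-c2nc3ccccc3[nH]2)CCN1C(=O)Cn1cnc2cccnc21` differs from compound 1 in one place: a group of 9 heavy atoms (6 carbon, 3 nitrogen; one five-membered aromatic ring with 2 hetero atoms, one six-membered aromatic ring with 1 hetero atom) in place of a group of 5 heavy atoms (3 carbon, 2 nitrogen; one five-membered aromatic ring with 2 hetero atoms), on a saturated chain carbon bound to a carbonyl carbon. Within the data shown here, nothing measured so far carries this group, and the two measured compounds differ from each other in more than one place, so no comparison tells how the change will read.

Among the measured compounds shown here, with no measured step to rest on, the step from compound 1 to compound 3 is expected to be no larger than the usual scatter, and its direction is left open; the estimate is a 1.2-fold lower number from compound 1 to compound 3 (0.08 log units; within the scatter). Compound 3 is estimated at 160 nM in this assay, with a range from 60 nM to 450 nM.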

Compound 3, half-maximal inhibitory concentration in the C-X-C chemokine receptor type 3 assay: 70 nM
For compound 3 the middle estimate is 2.3-fold (0.36 log units) above the measured one; the measured number falls inside the stated range.
By their numbers in the C-X-C chemokine receptor type 3 assay, from the lowest: compounds 3, 2 and 1 (each within the scatter of the next, the first and the last beyond it).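

On the saturated chain carbon bound to a carbonyl carbon, the result shows that the group in compound 3 reads better than 1H-pyrazol-1-yl in the C-X-C chemokine receptor type 3 assay, with a 2.7-fold lower number from compound 1 to compound 3 (0.44 log units; beyond the scatter). In a physicochemical assay for solubility, in simulated intestinal fluid (on this read-out higher numbers stand for higher solubility and lower numbers for lower solubility), compound 1 gives 352 ug/mL and compound 3 gives 13 ug/mL. The same change therefore moves both read-outs in opposite directions of benefit, and the loss of solubility is the larger move: the measured solubility of compound 1, 352 ug/mL, and of compound 3, 13 ug/mL, a 27-fold lower number (1.43 log units; beyond the scatter)

With a single pair at this position, the compounds shown do not separate the effect of the added six-membered aromatic ring from that of the larger group as a whole. As far as these compounds go, whether a group such as a morpholine or a carboxylic acid on the same chain carbon could combine the number of compound 3 in the C-X-C chemokine receptor type 3 assay with that of compound 1 in the physicochemical assay remains open.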